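From 4-nitrophenyl to 3-chlorophenyl in a weak series

The source may report more compounds than this note shows. Statements on the series, on what has been measured and on what is new or still open speak of the compounds shown alone.

In a functional assay on A549 cells (Homo sapiens) for cytotoxicity, read by MTT assay, with a stated time of 72 h (on this read-out higher numbers stand for weaker inhibition and lower numbers for stronger inhibition), compound 1 (`CNC(=O)c1cc(Oc2ccc(NC(=O)c3nccc(-c4ccccc4)n3)cc2)ccn1`) gives 26200 nM. Compound 2 (`CNC(=O)c1cc(Oc2ccc(NC(=O)c3cc(-c4ccc(Br)cc4)ncn3)cc2)ccn1`) gives > 100000 nM, which is a limit of the assay and not a number. Compound 3 (`CNC(=O)c1cc(Oc2ccc(NC(=O)c3nccc(-c4ccc([N+](=O)[O-])cc4)n3)cc2)ccn1`) gives > 100000 nM, again a limit and not a number. That leaves little to go on, with the limit of > 100000 nM in this assay, at which 2 of the 3 values shown sit.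

Compound 4 (`CNC(=O)c1cc(Oc2ccc(NC(=O)c3nccc(-c4cccc(Cl)c4)n3)cc2)ccn1`) carries 3-chlorophenyl in place of 4-nitrophenyl on an aromatic carbon. For the measured compounds named here, the only measured step that bears on this change is an at least 3.8-fold higher number from compound 1 to compound 3 (0.58 log units; beyond the scatter), in which nitro took the place of hydrogen on an aromatic carbon. Going by the values given here, compound 4 gives up that nitro group, so it is expected to move back towards compound 1 at 26200 nM, although its chlorine has no measured precedent here. The estimated step, towards a lower number and so stronger inhibition, is an at least 1.8-fold lower number from compound 3 to compound 4 (0.25 log units; that floor lies within the scatter). The estimated value for compound 4 is 55000 nM, with an expected range of 20000 nM to 130000 nM.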

Compound 4, half-maximal inhibitory concentration: > 100000 nM
Compound 4: a limit, no number (the forecaster's own chance of this, stated with the estimate: 40%); middle value at least 1.8-fold (0.25 log units) from the limit.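

In this assay, chloro in place of hydrogen on the phenyl ring gives an at least 3.8-fold higher number from compound 1 to compound 4 (0.58 log units; beyond the scatter), so the loss of a readable number is not confined to the nitro group: of the three compounds that differ only on this phenyl ring, only the unsubstituted compound 1 gives one. Compound 3 and compound 4 each give a limit of the assay and not a number, so the step between them cannot be read, and swapping 4-nitrophenyl for 3-chlorophenyl shows no measurable recovery. The series is now pressed even harder against its ceiling: the limit of > 100000 nM in this assay, at which 3 of the 4 values shown sit.

Going by these compounds, whether an amine or a hydroxyl group on this phenyl ring would keep a readable number, or give a lower one than compound 1, stays open. With one nitro compound and one chloro compound, the effect of the group also cannot be separated from the effect of where it sits on the ring.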